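The source may report more compounds than this note shows. Statements on the series, on what has been measured and on what is new or still open speak of the compounds shown alone.

Compound 3 `O=C(O)CC/C=C\CO[C@H]1C(OCc2ccc(-c3ccccc3CCO)cc2)CC[C@@H]1N1CCCCCC1` gives the lowest number of the three measured here: in a functional assay on blood for antagonist activity at thromboxane A2 receptor (Homo sapiens) (on this read-out higher numbers stand for weaker binding and lower numbers for tighter binding), compound 3 reads 2 nM. Its nearest neighbour is compound 1 `NC(=O)Cc1ccccc1-c1ccc(COC2CC[C@H](N3CCCCCC3)[C@H]2OC/C=C\CCC(=O)O)cc1`, which in this assay gives 7.94 nM, and furthest away lies compound 2 `O=C(O)CC/C=C\CO[C@@H]1[C@@H](OCc2ccc(-c3ccccc3)cc2)CC[C@@H]1N1CCCCC1`, which gives 100 nM; compound 2 differs from compound 3 in more than one place, so its value shows only the gap. Going by the values given here, the one single-site step on record runs from compound 1 to compound 3, where a 4.0-fold lower number from compound 1 to compound 3 (0.60 log units; beyond the scatter).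

Compound 4 `CC(=O)NCc1ccc(-c2ccc(COC3CC[C@H](N4CCCCCC4)[C@H]3OC/C=C\CCC(=O)O)cc2)cc1` is reached from compound 3 by 4-(acetamidomethyl)phenyl in place of 2-(2-hydroxyethyl)phenyl on an aromatic carbon. The group that leaves carries the hydroxyethyl chain close to the link between the two rings, while the group that enters sits para to a large group and carries an amide instead. The measured step from compound 1 to compound 3 shows that swapping one small polar tail for another on this outer ring shifts the number by a modest amount, and the change here moves the tail to a new place on the ring besides, for which no direct comparison exists. Compound 4 is therefore expected to give a somewhat higher number than compound 3, with a 5.0-fold higher number from compound 3 to compound 4 (0.70 log units; beyond the scatter), and an estimate of 10 nM in this assay, within a range from 3 nM to 40 nM.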

Compound 4, dissociation constant: 2.51 nM
Estimate against measurement, compound 4: 4.0-fold (0.60 log units) above, and the stated range ends above it.
By their numbers in this assay, from the lowest: compounds 3 and 4 (each within the scatter of the next); then compound 1; then compound 2.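

The step shows a 1.3-fold higher number from compound 3 to compound 4 (0.10 log units; within the scatter) in this assay, so 4-(acetamidomethyl)phenyl, para to a large group, and 2-(2-hydroxyethyl)phenyl cannot be told apart on this read-out, even though the tail differs in both its makeup and its place on the ring. The earlier step changed the tail alone, whereas this one shows that a low number can survive a change of both at once, with the larger group of 11 heavy atoms entering in place of one of 9. The comparison with the other amide-bearing compound gives a 3.2-fold lower number from compound 1 to compound 4 (0.50 log units; beyond the scatter), so among these compounds the presence of an amide in the tail does not by itself set the number.

Going by these compounds, the tail and its place changed together, so their separate contributions remain unknown, as does whether an amine or a carboxylic acid in place of the acetamidomethyl tail would keep the number this low. Nothing available here accounts for why these groups read as they do.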